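Cyclopropyl to isopropyl on a shared dihydroxyheptenoic acid scaffold

The source may hold more compounds than are shown below. What is called first, only, known or untested is meant among the compounds shown, and "the series" means these compounds.

The study concerns two measured compounds and one still to be measured, all carrying the same dihydroxy acid side chain and a 4-fluorophenyl group. Compound 1 `CC(C)c1nc2cc(-c3ccccc3)nn2c(-c2ccc(F)cc2)c1/C=C/[C@@H](O)C[C@@H](O)CC(=O)O` and compound 2 `Cc1cc2nc(C3CC3)c(/C=C/[C@@H](O)C[C@@H](O)CC(=O)O)c(-c3ccc(F)cc3)n2n1` were tested in an in vivo functional assay on the whole organism for inhibition of 3-hydroxy-3-methylglutaryl-coenzyme A reductase (Rattus norvegicus), at a dose of 2 mg/kg by the oral route; on this read-out higher numbers stand for a stronger effect at the one dose given and lower numbers for a weaker effect. In this assay compound 1 gives 24.1%, while compound 2 gives 6.5%, the lower of the two numbers, and the gap between them is beyond the usual scatter. Compound 1 and compound 2 differ in more than one place, so nothing can be attributed to any single change between them.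

Compound 3 `Cc1cc2nc(C(C)C)c(/C=C/[C@@H](O)C[C@@H](O)CC(=O)O)c(-c3ccc(F)cc3)n2n1` is the unmeasured compound. It differs from compound 2 in one place: isopropyl in place of cyclopropyl on an aromatic carbon. Going by the values given here, no single step of this kind has been measured here. The isopropyl group that enters is also the group present in compound 1, whose value of 24.1% is the higher of the two, but compound 1 differs elsewhere as well, so the expectation is cautious. Compound 3 is expected to show a modest rise, a number 6.5 percentage points higher from compound 2 to compound 3 (within the scatter), which may not clear the scatter. Compound 3 is estimated at 13%, within a range of 3% to 28%.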

Compound 3, a percentage reported as inhibition, in the whole organism at one dose (the size of the read-out at that dose, not a potency): -45.1%
Compound 3: middle estimate off by 58.1 percentage points, on the high side; the measured number lies below the stated range.
By their numbers in this assay, from the lowest: compound 3; then compound 2; then compound 1.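

Replacing cyclopropyl with isopropyl on the aromatic carbon next to the ring nitrogen gives a number 51.6 percentage points lower from compound 2 to compound 3 (beyond the scatter) in this assay, so this position separates two groups that have the same count of carbon atoms and differ in the ring. Compound 3 reads -45.1% on this scale, a number below zero, which places the change well outside a small adjustment of the read-out. With isopropyl held in place, methyl in place of phenyl on an aromatic carbon gives a number 69.2 percentage points lower from compound 1 to compound 3 (beyond the scatter) in this assay, so isopropyl accompanies the highest number in this set alongside phenyl and the lowest alongside methyl, and the group alone does not set the read-out.

The compounds shown leave open how an ethyl or a cyclobutyl group at this position would read, and whether cyclopropyl would give a different number alongside phenyl in place of methyl. Nothing measured here accounts for either step.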